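Carbamate in place of an aryl amide in cytotoxicity

The source may report more compounds than this note shows. Statements on the series, on what has been measured and on what is new or still open speak of the compounds shown alone.

compound 1 `CCCCOC(=O)Nc1cc2nc(C3CCCCC3)[nH]c2cc1N(CCC)CCC`: in an ADME assay on Vero cells (Chlorocebus sabaeus) for cytotoxicity, read by resazurin assay, with a stated time of 3 days (on this read-out lower numbers stand for stronger inhibition and higher numbers for weaker inhibition), compound 1 is reported only as the limit > 100 ug/mL.
compound 2 `CCCOCC(=O)Nc1cc2nc(C3CCCCC3)[nH]c2cc1N(C)C`: in this assay compound 2 is reported only as the limit < 50 ug/mL.
compound 3 `CCN(CC)c1cc2[nH]c(C3CCCCC3)nc2cc1NC(=O)c1ccc(OC(F)(F)F)cc1`: in this assay compound 3 is reported only as the limit > 100 ug/mL.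

Compound 3 thus stands not at a number but at a limit, and it is one of the two values that sit at the upper limit (the limit of > 100 ug/mL in this assay, at which 2 of the 3 values shown sit). Among the compounds with values here, compound 2 is the single value at the lower limit (the limit of < 50 ug/mL in this assay, at which 1 of the 3 values shown sits). None of these compounds differs from another in a single place, so no measured step between them can be drawn.

Compound 4 `CCN(CC)c1cc2[nH]c(C3CCCCC3)nc2cc1NC(=O)OCCOCCOC` differs from compound 3 by 2-(2-methoxyethoxy)ethoxy in place of 4-(trifluoromethoxy)phenyl on a carbonyl carbon. Within the data shown here, the step has no measured counterpart. Compound 4 is expected to remain at the upper limit because compound 1, which also carries a carbamate, gives > 100 ug/mL. The step from compound 3 to compound 4 is therefore expected to be none beyond the scatter, a number no higher from compound 3 to compound 4 (the limit leaves the size open). Compound 4 is estimated at 100 ug/mL, with a range from 50 ug/mL to 200 ug/mL.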

Compound 4, half-maximal inhibitory concentration: > 100 ug/mL
Compound 4: no number, only a limit; the forecaster's own chance of this, stated with the estimate: 70%; the middle value lies on the limit itself.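

Compound 3 and compound 4 both stand at a limit rather than a number in this assay, so no step between them can be read: the limit of > 100 ug/mL in this assay, at which 3 of the 4 values shown sit.

The compounds shown leave open whether 2-(2-methoxyethoxy)ethoxy in place of 4-(trifluoromethoxy)phenyl changes cytotoxicity at all.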